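The source may report more compounds than this note shows. Statements on the series, on what has been measured and on what is new or still open speak of the compounds shown alone.

In a functional assay on Jurkat cells (Homo sapiens) for inhibition (on this read-out lower numbers stand for stronger inhibition and higher numbers for weaker inhibition), compound 1, with structure `CC(C)[C@H](NC(=O)COc1cccc2ccccc12)C(=O)N[C@@H](CC(=O)O)C(=O)COc1cc(C(F)(F)F)n(C)n1`, gives 46000 nM. Compound 2, with structure `CCOC(=O)c1c(C)noc1OCC(=O)[C@H](CC(=O)O)NC(=O)[C@@H](NC(=O)COc1cccc2ccccc12)C(C)C`, is a different case: in this assay compound 2 gives only > 200000 nM, which is a limit of the assay and not a number. The step of an at least 4.3-fold higher number from compound 1 to compound 2 (0.63 log units; beyond the scatter) therefore rests on the limit of > 200000 nM in this assay, at which 1 of the 2 values shown sits, and shows only a lower bound of its size.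

Compound 3, with structure `CC(C)c1cc(OCC(=O)[C@H](CC(=O)O)NC(=O)[C@@H](NC(=O)COc2cccc3ccccc23)C(C)C)no1`, is not yet measured. It differs from compound 2 by 5-isopropyl-1,2-oxazol-3-yl in place of 4-(ethoxycarbonyl)-3-methyl-1,2-oxazol-5-yl on an oxygen on a saturated carbon. Among the compounds with values here, the single measured step bears on this position, as it also swapped the group on that oxygen, and it was at least modest in this assay. Whether the isoxazole of compound 3 falls closer to compound 1 or to compound 2 cannot be read from these two points alone. An inhibitory concentration for compound 3 is expected near 120000 nM, between 25000 nM and 400000 nM, which would mean a step of an at least 1.6-fold lower number from compound 2 to compound 3 (0.22 log units; that floor lies within the scatter).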

Compound 3, half-maximal inhibitory concentration: > 200000 nM
Compound 3: only a limit was reported; the forecaster's own chance of this, stated with the estimate: 45%; at least 1.6-fold (0.22 log units) between middle value and limit.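

In this assay compound 3 gives > 200000 nM, which is a limit of the assay and not a number. The step of an at least 4.3-fold higher number from compound 1 to compound 3 (0.63 log units; beyond the scatter) shows that a second 1,2-oxazole on this oxygen, this one with an isopropyl group and without the ethoxycarbonyl group of compound 2, also falls short of the 1-methyl-5-(trifluoromethyl)-1H-pyrazol-3-yl group of compound 1. The step between compound 2 and compound 3 cannot be read, since neither has a number, so the two oxazole groups cannot be put in order: the limit of > 200000 nM in this assay, at which 2 of the 3 values shown sit.

Still open, on these data alone, is how the read-out would move with a methyl group in place of the trifluoromethyl group on the pyrazole of compound 1, which gives 46000 nM. A plain phenyl group on this oxygen would show whether any inhibition remains without a five-membered aromatic ring there.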